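Losing the Ester While the Benzyl Stays

A few compounds are considered here, and "the series" means these few. Any claim that something is new, unique, unknown or untested is made for them only; others in the source may bear on it.

Compound 1 `CCOC(=O)c1cc(-c2cc(OC)c(OC)c(OC)c2)c(-c2ccc(OC)c(OCc3ccccc3)c2)s1` has no exact number. In a functional assay on SGC-7901 cells (Homo sapiens) for antiproliferative activity, read by MTT assay, with a stated time of 72 h (on this read-out higher numbers stand for weaker inhibition and lower numbers for stronger inhibition), compound 1 reads > 100000 nM, which is a limit of the assay.

Compound 2 `CCOC(=O)c1cc(-c2cc(OC)c(OC)c(OC)c2)c(-c2ccc(OC)c(O)c2)s1` carries hydrogen in place of benzyl on an oxygen on an aromatic ring, and in this assay compound 2 gives 1580 nM. This only measured step is large: an at least 63-fold lower number from compound 1 to compound 2 (1.80 log units; beyond the scatter).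

Compound 3 `COc1ccc(-c2sccc2-c2cc(OC)c(OC)c(OC)c2)cc1OCc1ccccc1` keeps the benzyl and changes elsewhere: hydrogen in place of ethoxycarbonyl on an aromatic carbon. Within the data shown here, no measured step covers this change directly. Among the measured compounds shown here, compound 3 retains the benzyl, so with an at least 63-fold lower number from compound 1 to compound 2 (1.80 log units; beyond the scatter) as the only guide, just a modest move toward a lower number is expected in this assay. The estimated step is an at least 2.0-fold lower number from compound 1 to compound 3 (0.30 log units; that floor lies within the scatter). Compound 3 is expected at 50000 nM, within an estimated range of 8000 nM to 100000 nM.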

Compound 3, half-maximal inhibitory concentration: > 100000 nM
Compound 3: a limit, no number (the forecaster's own chance of this, stated with the estimate: 50%); middle value at least 2.0-fold (0.30 log units) away from the limit.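

In this assay compound 3 reads > 100000 nM, a limit of the assay. Compound 1 also stands at a limit, so no step between compound 1 and compound 3 can be read: the limit of > 100000 nM in this assay, at which 2 of the 3 values shown sit.

On these data alone, what the ethoxycarbonyl contributes while the benzyl stays in place remains open.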